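A few compounds are considered here, and "the series" means these few. Any claim that something is new, unique, unknown or untested is made for them only; others in the source may bear on it.

Measured compounds in a functional assay (aorta) with Rattus norvegicus as the target; on this read-out lower numbers stand for stronger inhibition and higher numbers for weaker inhibition:
- compound 1, `CCO/C(O)=C1\C(COCCNC(=O)c2cccnc2)=NC(C)=C(C(=O)OC)C1c1ccccc1Cl`: 15.9 nM
- compound 2, `CCO/C(O)=C1\C(COCCN(C)C(=O)NC)=NC(C)=C(C(=O)OC)C1c1ccccc1Cl`: 20 nM
- compound 3, `CCO/C(O)=C1\C(COCCNC(=O)NCCN2CCNC2=O)=NC(C)=C(C(=O)OC)C1c1ccccc1Cl`: 15.9 nM

These three share one core and differ only in the group carried on the side chain. Their numbers in this assay sit close together: the step of a 1.3-fold higher number from compound 1 to compound 2 (0.10 log units; within the scatter) and the step of a 1.3-fold lower number from compound 2 to compound 3 (0.10 log units; within the scatter) are both small, and no change at the digits printed from compound 1 to compound 3 (within the scatter). Compound 2 therefore stands within the scatter of both companions, with nothing to separate it from them.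

Compound 4, `CCO/C(O)=C1\C(COCCN(C)/C(=N/C)NC#N)=NC(C)=C(C(=O)OC)C1c1ccccc1Cl`, takes the same site one step further: a group of 6 heavy atoms (3 carbon, 3 nitrogen; no ring) in place of a group of 4 heavy atoms (2 carbon, 1 nitrogen, 1 oxygen; no ring), on an amine nitrogen. All three measured steps bear on this change, since each exchanged a group at this same side-chain position, and none moved the number beyond the scatter. The expected step of no change at the digits printed from compound 2 to compound 4 (within the scatter) is accordingly no change beyond the scatter. Compound 4 is estimated at 20 nM in this assay, in the range 8 nM to 50 nM.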

Compound 4, half-maximal inhibitory concentration: 25.1 nM
Estimate against measurement, compound 4: 1.3-fold (0.10 log units) below; the measured number falls inside the stated range.
By their numbers in this assay, from the lowest: compounds 1, 3, 2 and 4 (each within the scatter of the next).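

Among the compounds shown here, compound 4 is the first here to carry no carbonyl on this side-chain nitrogen, and in this assay swapping methylcarbamoyl for its nitrile-bearing group gives a 1.3-fold higher number from compound 2 to compound 4 (0.10 log units; within the scatter) with no separation beyond the scatter. The comparisons with the two larger groups read the same way: the group with the five-membered ring gives a 1.6-fold higher number from compound 3 to compound 4 (0.20 log units; within the scatter) and the group with the pyridine ring gives a 1.6-fold higher number from compound 1 to compound 4 (0.20 log units; within the scatter) in this assay. So across all four compounds, a carbonyl on this nitrogen is not needed to keep the number in this narrow band, and neither the ring nor the larger groups set any compound apart.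

A carboxylic acid or a free primary amine at the same place, or a shorter chain, remains an open test of how far this band extends. Nothing available here accounts for why these different groups give such close numbers.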